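Carbamoyl pyrazole series: cyano in place of methyl

The source may hold more compounds than are shown below. What is called first, only, known or untested is meant among the compounds shown, and "the series" means these compounds.

Compound 1 `Cc1cnn(C(=O)NCc2ccc(OC(c3ccccc3)c3ccccc3)cc2)c1` and compound 2 `Cc1cnn(C(=O)N(C)CCN(C)C(c2ccc(OCc3ccccc3)cc2)c2ccc(OCc3ccccc3)cc2)c1` share a carbamoyl pyrazole attached to a diaryl ether or diaryl methane fragment. In an assay on membranes from brain for binding affinity to Monoglyceride lipase (Mus musculus), read by fluorescence, with stated times of 1 h and 30 min (a lower number here means a stronger inhibitor, a higher number a weaker inhibitor), compound 1 gives only a limit, > 100000 nM. In this assay compound 2 likewise gives only a limit, > 1000000 nM. Both values thus sit at the edge of the assay, as recorded in the limit of > 100000 nM in this assay, at which 1 of the 2 values shown sits, and (the limit of > 1000000 nM in this assay, at which 1 of the 2 values shown sits); no number for either compound is known, and no comparison between them can be drawn.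

Compound 3 `CN(CCN(C)C(c1ccc(OCc2ccccc2)cc1)c1ccc(OCc2ccccc2)cc1)C(=O)n1cc(C#N)cn1` differs from compound 2 by one change, cyano in place of methyl on an aromatic carbon, two ring bonds from the ring nitrogen. Within the data shown here, no measured step of this kind is available. The step of an at least 10-fold lower number from compound 2 to compound 3 (1.00 log units; beyond the scatter) is expected to run toward stronger binding, though with wide uncertainty given that only limits are known. Compound 3 is estimated at 100000 nM in this assay, within a range from 5000 nM to 1000000 nM.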

Compound 3, half-maximal inhibitory concentration: 32000 nM
Beside the measured number, compound 3's estimate is 3.1-fold (0.49 log units) above it, and the stated range covers the measured number.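

In this assay, among these compounds, compound 3 gives 32000 nM, the first real number in this set rather than a limit, so this pyrazole carbon can move the read-out into the measurable range. Going from 4-methyl-1H-pyrazol-1-yl to 4-cyano-1H-pyrazol-1-yl, with the rest of the structure unchanged, gives an at least 31-fold lower number from compound 2 to compound 3 (1.49 log units; beyond the scatter). The true size of this step stays unknown because compound 2 has only a limit: the limit of > 1000000 nM in this assay, at which 1 of the 3 values shown sits.

Still open, from the compounds shown here alone, is whether the gain is particular to cyano or would also appear with a chlorine, a carboxylic acid or a primary amide on the same carbon. Also open, going by these compounds, is whether the same change would carry over to the diaryl ether fragment of compound 1.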